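Swapping a phenoxy for a methoxy on the shared core

This account rests on a few compounds, and the source may have more. Where it says the series, first, only, none or still open, it means among the compounds named here.

Of the compounds shown here, three sharing one core have been measured in a functional assay on PC-3 cells (Homo sapiens) for cytotoxicity, read by sulforhodamine B assay, with a stated time of 48 h; on this read-out higher numbers stand for weaker inhibition of growth and lower numbers for stronger inhibition of growth. Compound 1 `CC1=C(C(=O)Nc2ccc(Cl)c(Cl)c2)C(c2cccc(O)c2)NC(=S)N1`, with a hydroxy group on the aromatic ring and two chloro groups on the amide aryl, gives 14100 nM. Compound 2 `CC1=C(C(=O)Nc2ccc(F)c(Cl)c2)C(c2cccc(Oc3ccccc3)c2)NC(=S)N1`, with a phenoxy group and a fluoro beside a chloro on the amide aryl, gives 12000 nM. Compound 3 `CC1=C(C(=O)Nc2ccc(Cl)c(Cl)c2)C(c2cccc(Oc3ccccc3)c2)NC(=S)N1`, with the phenoxy and both chloro groups, gives 9770 nM; on these numbers it stands lowest, yet its gaps to both others are within the scatter, so no order among the three can be claimed.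

Compound 4 `COc1cccc(C2NC(=S)NC(C)=C2C(=O)Nc2ccc(Cl)c(Cl)c2)c1` differs from compound 3 in one place: methyl in place of phenyl on an oxygen on an aromatic ring. The step that bears on this change is the one at the same oxygen, a 1.4-fold lower number from compound 1 to compound 3 (0.16 log units; within the scatter), where hydrogen became phenyl. The step of a 1.2-fold lower number from compound 2 to compound 3 (0.09 log units; within the scatter) concerns the amide aryl and does not bear on it. Since a larger change at the oxygen moved the number only within the scatter, a methyl in place of phenyl is expected to bring no step beyond the scatter, a 1.1-fold higher number from compound 3 to compound 4 (0.05 log units; within the scatter). Compound 4 is therefore estimated at 11000 nM, between 5000 nM and 25000 nM.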

Compound 4, concentration for 50% growth inhibition: 14500 nM
Compound 4: the middle estimate sits 1.3-fold (0.12 log units) below what was measured; the measured number falls inside the stated range.
By their numbers in this assay, from the lowest: compounds 3, 2, 1 and 4 (each within the scatter of the next).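

Across compounds with the same two chloro groups on the amide aryl, the oxygen on the aromatic ring now carries hydrogen, phenyl or methyl. In this assay replacing the phenyl with a methyl, which removes a whole aromatic ring, gives a 1.5-fold higher number from compound 3 to compound 4 (0.17 log units; within the scatter) and adding a methyl to the bare hydroxy gives a 1.0-fold higher number from compound 1 to compound 4 (0.01 log units; within the scatter) so neither step can be told apart from the scatter. Among these three groups, then, what sits on this oxygen makes no readable difference to growth inhibition, and no measurement is at hand to explain this.

Still open, on these data alone, is whether a longer chain on this oxygen, or one ending in an amine or a carboxylic acid, would move the number beyond the scatter. It is also unknown whether this flat picture holds with the fluoro and chloro amide aryl of compound 2.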